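This account rests on a few compounds, and the source may have more. Where it says the series, first, only, none or still open, it means among the compounds named here.

Of the compounds shown here, three that share one core have been tested in a functional assay on HT-29 cells (Homo sapiens) for inhibition, read by sulforhodamine B assay, with a stated time of 72 h; on this read-out lower numbers stand for stronger inhibition of growth and higher numbers for weaker inhibition of growth. Compound 1 `CC(C)(C)OC(=O)NCCCCCN1C(Nc2ccc(-c3ccccc3)cc2)=Nc2ccccc2C1CC(=O)NCc1ccccc1` gives 1700 nM, compound 2 `CC(C)(C)OC(=O)NCCCCCNC1=Nc2ccccc2C(CC(=O)NCc2ccccc2)N1c1ccccc1` gives 3180 nM, and compound 3 `COC(=O)CC1c2ccccc2N=C(NCCCCCNC(=O)OC(C)(C)C)N1c1ccc(-c2ccccc2)cc1` gives 2080 nM. All three numbers lie within the usual scatter of one another, so compound 3 cannot be set apart from either neighbour. Compound 4 `CC(C)(C)OC(=O)NCCCCCNC1=Nc2ccccc2C(CC(=O)NCc2ccccc2)N1c1ccc(-c2ccccc2)cc1` differs from compound 3 in one place: benzylamino in place of methoxy on a carbonyl carbon. Compound 1 gives 1700 nM and compound 2 gives 3180 nM while already carrying the benzylcarbamoyl group, and both sit close to compound 3. On that basis the step is expected to be small, a 1.2-fold lower number from compound 3 to compound 4 (0.06 log units; within the scatter), with no direction beyond the scatter. Compound 4 is therefore estimated at 1800 nM, within a range from 700 nM to 5000 nM.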

Compound 4, concentration for 50% growth inhibition: 1670 nM
Estimate against measurement, compound 4: 1.1-fold (0.03 log units) above, and the stated range covers the measured number.
By their numbers in this assay, from the lowest: compounds 4, 1, 3 and 2 (each within the scatter of the next).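

In this assay, going by these compounds alone, benzylamino in place of methoxy on a carbonyl carbon gives a 1.2-fold lower number from compound 3 to compound 4 (0.10 log units; within the scatter) and so, in the first direct comparison at this position, adding an aromatic ring produces no change that stands out from the scatter. Phenyl in place of hydrogen on an aromatic carbon gives a 1.9-fold lower number from compound 2 to compound 4 (0.28 log units; within the scatter) and this step too lies within the scatter. Nothing available explains either result. Still open, as far as these compounds go, is whether a carboxylic acid or a simple primary amide on this carbonyl carbon would move the number beyond the scatter.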